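Solubility after replacing a thiophenyl sulfide with a propanamide

The source may report more compounds than this note shows. Statements on the series, on what has been measured and on what is new or still open speak of the compounds shown alone.

Compound 1, `O=C1O[C@@H](CO)CN1c1ccc(-n2cc(-c3ccccn3)cn2)c(F)c1`: 56400 nM in a physicochemical assay for solubility, read by HPLC, with a stated time of 24 h; on this read-out lower numbers stand for lower solubility and higher numbers for higher solubility
Compound 2, `O=C1O[C@@H](CSc2cccs2)CN1c1ccc(-n2cc(-c3ccccn3)cn2)c(F)c1`: 8500 nM in this assay

Compound 2 holds the lower of the two numbers. For the measured compounds named here, the only measured step, a 6.6-fold lower number from compound 1 to compound 2 (0.82 log units; beyond the scatter), is the one that bears on what follows, since compound 3, `CCC(=O)NC[C@H]1CN(c2ccc(-n3cc(-c4ccccn4)cn3)c(F)c2)C(=O)O1`, reverses part of it: propanoylamino in place of (thiophen-2-yl)sulfanyl on a saturated chain carbon bound to a saturated ring carbon. That step was modest but beyond the scatter, and the incoming group, with its hydrogen-bond donor and no ring, points back toward compound 1. Compound 3 is therefore expected to show a higher number in this assay, estimated at 35000 nM, within 12000 nM to 100000 nM. From compound 2 the expected step is a 4.1-fold higher number from compound 2 to compound 3 (0.61 log units; beyond the scatter).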

Compound 3, solubility: 147000 nM
Estimate against measurement, compound 3: 4.2-fold (0.62 log units) below; the whole stated range lies below it.
By their numbers in this assay, from the lowest: compound 2; then compound 1; then compound 3.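

In this assay the propanoylamino group more than recovers what the thiophenyl sulfide lost on this saturated chain carbon bound to a saturated ring carbon, with a 17-fold higher number from compound 2 to compound 3 (1.24 log units; beyond the scatter) in the step from the sulfide. It also passes the hydroxy group, with a 2.6-fold higher number from compound 1 to compound 3 (0.42 log units; beyond the scatter) at the same place, so hydroxy does not mark the top of the range here. Nothing measured explains either step. Still open, going by these compounds, is whether the amide hydrogen or the chain carries the difference, and whether an amine, a carboxylic acid or a longer butanoylamino chain on this carbon would read higher or lower.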